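The source may hold more compounds than are shown below. What is called first, only, known or untested is meant among the compounds shown, and "the series" means these compounds.

Compound 1 `C/C(=N\NC(=S)Nc1ccccc1I)c1ccccn1`: 4.1 nM
Compound 2 `C/C(=N/NC(=S)Nc1ccc(Cl)cc1)c1ccccn1`: 8.49 nM

Going by the values given here, in a functional assay on MCF7 cells (Homo sapiens) for cytotoxicity, read by MTT assay, with a stated time of 48 h (on this read-out lower numbers stand for stronger inhibition and higher numbers for weaker inhibition), compound 1 gives 4.1 nM, the lower of the two numbers so far. Compound 2 gives 8.49 nM, and the gap between them lies beyond the usual scatter of repeat measurements. Compound 1 therefore sets the mark for the next comparison.

Compound 3 `C/C(=N\NC(=S)Nc1ccccc1F)c1ccccn1` keeps the core of compound 1 and changes one substituent, with fluoro in place of iodo on an aromatic carbon. Only the halogen differs, and the swap adds no ring, no charge and no hydrogen-bond donor or acceptor. Among the compounds with values here, no measured pair in this small set isolates a single change, so the data offer no direct guide to the size of this step. A cautious expectation is therefore a small shift, with no move beyond the scatter as the likeliest outcome and a slight lean toward a higher number. In this assay the expected change is a 1.7-fold higher number from compound 1 to compound 3 (0.23 log units; within the scatter). The estimate for compound 3 is 7 nM, with an expected range from 2 nM to 25 nM.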

Compound 3, half-maximal inhibitory concentration: 0.39 nM
Beside the measured number, compound 3's estimate is 18-fold (1.25 log units) above it; the measured number lies below the stated range.
By their numbers in this assay, from the lowest: compound 3; then compound 1; then compound 2.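

In this assay, the group on this aromatic carbon, ortho to a large group, turns out to matter a great deal: fluoro in place of iodo gives an 11-fold lower number from compound 1 to compound 3 (1.02 log units; beyond the scatter) and so lies well beyond the scatter of repeat measurements. Going by these compounds alone, this is the first pair in the set that differs in one place only, and it gives the first direct sign that the read-out responds strongly to the halogen at this position, even though the swap adds no ring, no charge and no hydrogen-bond donor or acceptor. No measurement shown here explains the size of this step, so its cause stays unknown.

On these data alone, a single step between two halogens cannot show a trend, so it remains open where a bromo group would fall, and how the number would respond to a plain hydrogen, a methoxy group or an amine at the same carbon. As far as these compounds go, it is also open whether the same swap from iodo to fluoro would give a step of similar size at another carbon of this ring.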